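A Bulkier Aryl Group on Compound 2

A few compounds are considered here, and "the series" means these few. Any claim that something is new, unique, unknown or untested is made for them only; others in the source may bear on it.

In a functional assay on A549 cells (Homo sapiens) for cytotoxicity, read by MTT assay, with a stated time of 72 h (on this read-out lower numbers stand for stronger inhibition and higher numbers for weaker inhibition), compound 1 `Cn1ccc2c(Oc3ccc(NC(=O)c4cc5cccnc5n(-c5ccc(F)cc5)c4=O)cc3F)ncnc21` gives 7320 nM and compound 2 `O=C(Nc1ccc(Oc2ncnc3[nH]ccc23)c(F)c1)c1cc2cccnc2n(-c2ccc(F)cc2)c1=O` gives 5290 nM as its value, so these two stand level within the scatter. Within the data shown here, the one measured step is a 1.4-fold lower number from compound 1 to compound 2 (0.14 log units; within the scatter) and it concerns another part of the molecule, so it offers little guidance here. Compound 3 `O=C(Nc1ccc(Oc2ncnc3[nH]ccc23)c(F)c1)c1cc2cccnc2n(-c2ccc(C(F)(F)F)cc2Cl)c1=O` differs from compound 2 by 2-chloro-4-(trifluoromethyl)phenyl in place of 4-fluorophenyl on an aromatic nitrogen with 2-chloro-4-(trifluoromethyl)phenyl in place of 4-fluorophenyl on an aromatic nitrogen. No step beyond the scatter is expected, and the estimated 1.4-fold lower number from compound 2 to compound 3 (0.14 log units; within the scatter) stays small. In this assay compound 3 is expected at 3800 nM within a range of 1200 nM to 12000 nM as a rough guide.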

Compound 3, half-maximal inhibitory concentration: 283000 nM
Beside the measured number, compound 3's estimate is 74-fold (1.87 log units) below it; measured number above the stated range.
By their numbers in this assay, from the lowest: compounds 2 and 1 (each within the scatter of the next); then compound 3.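

This position on the aromatic nitrogen is sensitive to the choice of aryl group: in this assay, 2-chloro-4-(trifluoromethyl)phenyl in place of 4-fluorophenyl brings a 53-fold higher number from compound 2 to compound 3 (1.73 log units; beyond the scatter), a large step, whereas the earlier change elsewhere in the molecule stayed within the scatter. The entering group adds a chlorine and replaces the fluorine with trifluoromethyl, so this one step cannot separate the two changes. Nothing measured here explains the size of this step. From the compounds shown here alone, it remains open which of the two substituents accounts for the step, and whether a plain phenyl ring or a methoxy group on the ring would keep the number low.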